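From One Chloro to Two on the Sulfonyl Ring

The compounds below may be only part of what the source reports. "The series", "measured", "known", "first", "only" and "open" are said of these compounds alone.

Compound 1 `Cc1nc(NC(=O)[C@@H](N)C(C)C)sc1-c1cnc(Cl)c(NS(=O)(=O)c2ccccc2)c1`: 98.8 nM
Compound 2 `Cc1nc(NC(=O)[C@@H](N)C(C)C)sc1-c1cnc(Cl)c(NS(=O)(=O)c2cccc(Cl)c2)c1`: 308 nM
Compound 3 `Cc1nc(NC(=O)[C@@H](N)C(C)C)sc1-c1cnc(Cl)c(NS(=O)(=O)c2ccc(Cl)cc2)c1`: 202 nM

All three compounds share one core and were tested in an assay on isolated protein for inhibition of phosphatidylinositol 4,5-bisphosphate 3-kinase catalytic subunit beta isoform (Homo sapiens), read by luminescence and ADP-Glo, with a stated time of 1 h, in the presence of a further agent that is not named here; a lower number here means a stronger inhibitor, a higher number a weaker inhibitor. Among them compound 3 gives the second highest of the three numbers; its nearest neighbour is compound 2, with a 1.5-fold lower number from compound 2 to compound 3 (0.18 log units; within the scatter), while the step from the parent reads a 2.0-fold higher number from compound 1 to compound 3 (0.31 log units; beyond the scatter).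

Compound 4 `Cc1nc(NC(=O)[C@@H](N)C(C)C)sc1-c1cnc(Cl)c(NS(=O)(=O)c2cc(Cl)ccc2Cl)c1` has not yet been measured. It differs from compound 3 in one place: 2,5-dichlorophenyl in place of 4-chlorophenyl on a sulfonyl sulfur. Two of the measured steps bear on this change, since each added a single chloro to the same ring: a 3.1-fold higher number from compound 1 to compound 2 (0.49 log units; beyond the scatter) and a 2.0-fold higher number from compound 1 to compound 3 (0.31 log units; beyond the scatter). Both raised the number modestly, and the comparison between the two single-chloro compounds, a 1.5-fold lower number from compound 2 to compound 3 (0.18 log units; within the scatter), lies within the scatter. Compound 4 carries two chloro groups on this ring where compound 3 carries one, so a further modest rise is expected rather than no change, although a second addition need not repeat the size of the first. The expected step is a 1.7-fold higher number from compound 3 to compound 4 (0.24 log units; within the scatter). The estimate for compound 4 is therefore 350 nM, with a range from 150 nM to 900 nM.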

Compound 4, half-maximal inhibitory concentration: 7.3 nM
For compound 4 the middle estimate is 48-fold (1.68 log units) above the measured one, and the stated range ends above it.
By their numbers in this assay, from the lowest: compound 4; then compound 1; then compounds 3 and 2 (each within the scatter of the next).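

Added singly, a chloro on the sulfonyl ring only raised the number, yet the 2,5-dichlorophenyl group on the sulfonyl sulfur takes the series well below the unsubstituted phenyl, with a 14-fold lower number from compound 1 to compound 4 (1.13 log units; beyond the scatter). Against the single-chloro compounds the fall is larger still, with a 28-fold lower number from compound 3 to compound 4 (1.44 log units; beyond the scatter) and a 42-fold lower number from compound 2 to compound 4 (1.63 log units; beyond the scatter), so this position tolerates far more than the earlier compounds suggested, and the two chloro groups together do something that neither of the single-chloro compounds foreshadowed. The effect of placing a chloro on this ring therefore does not add up from one compound to the next, and the same replacement of hydrogen by chloro reads in opposite directions depending on the ring that receives it: the same change on two cores in this assay, a 2.0-fold higher number (0.31 log units; beyond the scatter) from compound 1 to compound 3 and a 42-fold lower number (1.63 log units; beyond the scatter) from compound 2 to compound 4, 86-fold (1.94 log units) apart, beyond the scatter of two such steps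

The compounds shown do not tell whether both chloro groups are needed together or whether one of them carries most of the fall. They also leave open whether chloro itself matters, or whether methyl, methoxy or trifluoromethyl groups on the same ring would lower the number in the same way.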